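Swapping the methylphenyl for pyridyl on the hydrazide carbonyl

The compounds below may be only part of what the source reports. "The series", "measured", "known", "first", "only" and "open" are said of these compounds alone.

Measured so far:
- compound 1 `Cc1ccc(C(=O)N/N=C/C2=C(Cl)c3ccccc3CCC2)cc1`: in a functional assay on HeLa cells (Homo sapiens) for inhibition, read by sulforhodamine B assay, with a stated time of 48 h (on this read-out lower numbers stand for stronger inhibition of growth and higher numbers for weaker inhibition of growth), compound 1 gives 300 nM
- compound 2 `O=C(N/N=C/C1=C(Cl)c2ccccc2CCC1)c1ccc([N+](=O)[O-])cc1`: compound 2 gives > 100000 nM, which is a limit of the assay and not a number

Compound 1 holds the only number shown in this assay. For compound 2 the reported value is a limit, (the limit of > 100000 nM in this assay, at which 1 of the 2 values shown sits). Putting nitro in place of methyl on that aromatic ring brought an at least 330-fold higher number from compound 1 to compound 2 (2.52 log units; beyond the scatter). Compound 3 `O=C(N/N=C/C1=C(Cl)c2ccccc2CCC1)c1cccnc1` alters the same ring in another way: pyridin-3-yl in place of 4-methylphenyl on a carbonyl carbon. Within the data shown here, the only measured step touching this ring was large, but it exchanged a different group, so it guides the expectation only loosely. A moderate weakening is expected, a 5.0-fold higher number from compound 1 to compound 3 (0.70 log units; beyond the scatter). Compound 3 is therefore estimated at 1500 nM, with a range from 300 nM to 10000 nM.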

Compound 3, concentration for 50% growth inhibition: 7500 nM
For compound 3 the middle estimate is 5.0-fold (0.70 log units) below the measured one; the range from low to high includes it.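

Pyridin-3-yl on the carbonyl carbon brings a 25-fold higher number from compound 1 to compound 3 (1.40 log units; beyond the scatter) and makes this the second change at this ring to weaken growth inhibition, now with a size that can be read as a real number. Compound 3 still inhibits growth measurably at 7500 nM in this assay. Compound 2, by contrast, gives only a limit of the assay and not a number: the limit of > 100000 nM in this assay, at which 1 of the 3 values shown sits.

On these data alone, compound 3 swaps a ring carbon for nitrogen and loses the methyl at once, and which of the two goes with the loss stays open. An unsubstituted phenyl or a methylpyridinyl on this carbonyl carbon would tell them apart.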